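Two weak inhibitors and one methyl group

The source may report more compounds than this note shows. Statements on the series, on what has been measured and on what is new or still open speak of the compounds shown alone.

Compound 1 `C#Cc1cccc(Nc2ncnc3cc(NC(=O)/C=C/c4ccccc4)sc23)c1` gives 15400 nM
Compound 2 `O=C(/C=C/c1ccc(O)cc1)Nc1cc2c(Nc3ccc(Cl)c(Cl)c3)ncnc2s1` gives 42900 nM

Both values come from a functional assay on HepG2 cells (Homo sapiens) for antiproliferative activity, read by MTT assay, with a stated time of 48 h (a lower number here means a stronger inhibitor, a higher number a weaker inhibitor), and lie further apart than the usual scatter of repeated measurements. Compound 2 has the higher number of the two, which makes it the weaker inhibitor of this pair. Compound 3 `COc1ccc(/C=C/C(=O)Nc2cc3c(Nc4ccc(Cl)c(Cl)c4)ncnc3s2)cc1` is compound 2 with one change, methyl in place of hydrogen on an oxygen on an aromatic ring in which hydroxy becomes methoxy, or 4-hydroxyphenyl becomes 4-methoxyphenyl. Going by the values given here, no two measured compounds show this change on their own, so the main guide is compound 2 at 42900 nM in this test. The expected 1.2-fold lower number from compound 2 to compound 3 (0.09 log units; within the scatter) is small, with no shift beyond the scatter in either direction. Compound 3 is estimated at 35000 nM with 15000 nM to 80000 nM as its expected range.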

Compound 3, half-maximal inhibitory concentration: 30600 nM
Beside the measured number, compound 3's estimate is 1.1-fold (0.06 log units) above it; measured number inside the range.
By their numbers in this assay, from the lowest: compounds 1, 3 and 2 (each within the scatter of the next, the first and the last beyond it).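

Putting methyl on the oxygen of the 4-hydroxyphenyl group, so that hydroxy becomes methoxy, gives a 1.4-fold lower number from compound 2 to compound 3 (0.15 log units; within the scatter) in this assay. Going by these compounds alone, this is the first single-place comparison, and it shows that at this position the hydrogen on the oxygen can be replaced by methyl with no shift beyond the scatter, so the result does not depend on that hydrogen being present. No independent measurement bears on why this exchange leaves the number within the scatter.

A single step at one position cannot show how far this tolerance reaches: a longer chain on the oxygen, such as ethoxy, or an amine or a carboxylic acid in place of the hydroxy might behave differently. From the compounds shown here alone, it also remains open whether the same exchange would give a similar result with the core and the aniline part of compound 1.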